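The source may hold more compounds than are shown below. What is called first, only, known or untested is meant among the compounds shown, and "the series" means these compounds.

In an ADME assay on BJ cells (Homo sapiens), read by MTT assay, with a stated time of 72 h (on this read-out higher numbers stand for weaker inhibition and lower numbers for stronger inhibition), three close relatives of one shared core have been tested. Compound 1 `COc1nc(N)nc2c1c(-c1ccccc1)cn2[C@@H]1O[C@H](CO)[C@@H](O)[C@H]1O` reaches only the limit of the assay, > 100000 nM, and not a measured number. Compound 2 `COc1nc(N)nc2c1c(-c1cccs1)cn2[C@@H]1O[C@H](CO)[C@@H](O)[C@H]1O` gives 99900 nM. Compound 3 `CNc1ncnc2c1c(-c1ccccc1)cn2[C@@H]1O[C@H](CO)[C@@H](O)[C@H]1O` has a core that differs from that of compound 1 in a way that is not broken down here. Compound 3 likewise reaches only the limit of the assay, > 100000 nM, not a number. The change from compound 1 to compound 2 is thiophen-2-yl in place of phenyl on an aromatic carbon. As far as these compounds go, it made a number no higher from compound 1 to compound 2 (the limit leaves the size open); because two of the three values sit at the limit of > 100000 nM in this assay, at which 2 of the 3 values shown sit, the true size of that step stays open. Compound 4 `CNc1ncnc2c1c(-c1cccs1)cn2[C@@H]1O[C@H](CO)[C@@H](O)[C@H]1O` has not yet been measured. It differs from compound 3 by thiophen-2-yl in place of phenyl on an aromatic carbon, the same kind of change as before, though here the place is described only as bearing a group of 9 heavy atoms rather than the named 3,4-dihydroxy-5-(hydroxymethyl)oxolan-2-yl group. The step from compound 3 to compound 4 is expected to be a number no higher from compound 3 to compound 4 (the limit leaves the size open), set beside a number no higher from compound 1 to compound 2 (the limit leaves the size open), an expectation resting on the fact that compound 1 and compound 3 both stand at the limit of > 100000 nM in this assay, at which 2 of the 3 values shown sit. Compound 4 is therefore expected at about 100000 nM, within a range from 50000 nM to 200000 nM.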

Compound 4, half-maximal inhibitory concentration: > 100000 nM
Compound 4 ended at the assay's limit (the forecaster's own chance of this, stated with the estimate: 60%); the middle value sits exactly at the limit.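

No size can be read for the change from compound 3 to compound 4 because both compounds give only a limit and no measured number: the limit of > 100000 nM in this assay, at which 3 of the 4 values shown sit.

The compounds shown leave open whether thiophen-2-yl in place of phenyl changes the result at all in this assay on the core shared by compound 3 and compound 4.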